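The compounds below may be only part of what the source reports. "The series", "measured", "known", "first", "only" and "open" are said of these compounds alone.

The set comprises four analogues that share a nitrile-bearing core and a cyclohexylmethyl side chain carrying a morpholine amide. Compound 1 `N#C[C@@]1(NC(=O)[C@@H](CC(=O)N2CCOCC2)CC2CCC(c3ccccc3)CC2)CCN(C2CCCCC2)C1` has no result in an assay on isolated protein for inhibition of cathepsin S (Homo sapiens) (on this read-out higher numbers stand for weaker binding and lower numbers for tighter binding), where compound 1 is recorded as "not determined" (no result reported), and compound 2 `N#C[C@@]1(NC(=O)[C@@H](CC(=O)N2CCOCC2)CC2CCCCC2)CCN(C2CCCC2)C1` likewise stands without a number in this assay, where compound 2 is recorded as "not determined" (no result reported), so nothing can be read of where compound 2 sits. Among the compounds with values here, compound 3 `N#CC1(NC(=O)[C@@H](CC(=O)N2CCOCC2)CC2CCCCC2)CC1`, whose core is a small carbocycle rather than the nitrogen-containing ring of the other members, is the only one with a value: in this assay compound 3 gives 12 nM. Compound 4 `N#C[C@@]1(NC(=O)[C@@H](CC(=O)N2CCOCC2)CC2CCCCC2)CCN(C2CCCCCC2)C1` remains to be measured in this assay. Relative to compound 2, compound 4 carries cycloheptyl in place of cyclopentyl on an amine nitrogen in a ring. Within the data shown here, since compound 2 has no result, no step can be drawn and no direction can be supported from the data; compound 3 serves only as a loose point of reference for the series. On that basis, compound 4 is expected in this assay to give around 20 nM, with an estimated range from 3 nM to 150 nM.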

Compound 4, dissociation constant: 11 nM
Beside the measured number, compound 4's estimate is 1.8-fold (0.26 log units) above it; low and high end bracket the measured number.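

In this assay, within the data shown here, compound 2 is recorded as "not determined" (no result reported) and compound 4 gives 11 nM so no step between the two can be read. The compounds shown leave open how cycloheptyl compares with cyclopentyl on the amine nitrogen in a ring. No evidence bearing on this result is available.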